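Swapping the ring attachment for a two-carbon linker

The source may hold more compounds than are shown below. What is called first, only, known or untested is meant among the compounds shown, and "the series" means these compounds.

Compound 1: `CC(C(=O)NCc1ccc(C(F)(F)F)nc1C1CCC(C)(C)CC1)c1ccc(NS(C)(=O)=O)c(F)c1` gives 0.4 nM in an assay on CHO cells for antagonist activity at transient receptor potential cation channel subfamily V member 1 (Homo sapiens), read by FLIPR and calcium flux; on this read-out higher numbers stand for weaker inhibition and lower numbers for stronger inhibition. Compound 2: `CCC1CC=C(c2nc(C(F)(F)F)ccc2CNC(=O)C(C)c2ccc(NS(C)(=O)=O)c(F)c2)CC1` gives 0.1 nM in this assay. Compound 3: `CC(C(=O)NCc1ccc(C(F)(F)F)nc1C1=CCC(C(C)(C)C)CC1)c1ccc(NS(C)(=O)=O)c(F)c1` gives 0.2 nM in this assay.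

Among these three measured numbers compound 3 stands second highest. Its neighbours are compound 1, separated by the step of a 2.0-fold lower number from compound 1 to compound 3 (0.30 log units; within the scatter), and compound 2, separated by the step of a 2.0-fold higher number from compound 2 to compound 3 (0.30 log units; within the scatter); both steps lie within the usual scatter, so the three cannot be ordered with confidence. Within the data shown here, only the step of a 4.0-fold lower number from compound 1 to compound 2 (0.60 log units; beyond the scatter) reaches beyond the scatter.

Compound 4, `CC(C(=O)NCc1ccc(C(F)(F)F)nc1/C=C/C1CCCCC1)c1ccc(NS(C)(=O)=O)c(F)c1`, is the unmeasured candidate. It changes compound 3 by 2-cyclohexylethenyl in place of 4-(tert-butyl)cyclohex-1-en-1-yl on an aromatic carbon. Among the measured compounds shown here, none of the measured steps inserts a two-carbon linker between the shared core and the ring; they only reshape or resaturate the ring and its substituents, and all of them stay small. For the measured compounds named here, with no direct precedent, the expectation for compound 4 is a step of a 2.5-fold higher number from compound 3 to compound 4 (0.40 log units; beyond the scatter), a weakening of similar small size, carrying wide uncertainty. Compound 4 is therefore estimated at 0.5 nM, expected to fall between 0.1 nM and 3 nM.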

Compound 4, inhibition constant: 0.7 nM
For compound 4 the middle estimate is 1.4-fold (0.15 log units) below the measured one, and the stated range covers the measured number.
By their numbers in this assay, from the lowest: compounds 2, 3, 1 and 4 (each within the scatter of the next, the first and the last beyond it).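

In this assay, the 2-cyclohexylethenyl group, which sets its ring apart from the aromatic carbon next to the ring nitrogen, gives a 3.5-fold higher number from compound 3 to compound 4 (0.54 log units; beyond the scatter) and a 7.0-fold higher number from compound 2 to compound 4 (0.85 log units; beyond the scatter), so it falls short of both cyclohexenyl groups attached directly to that carbon. Against the saturated 4,4-dimethylcyclohexyl group the change gives a 1.8-fold higher number from compound 1 to compound 4 (0.24 log units; within the scatter), and compound 4, at 0.7 nM, still inhibits strongly, so this position accepts a ring held on a link at only a modest cost. Nothing measured here explains that cost.

Compound 4 also lacks any substituent on its ring, so the effect of the link cannot be separated from the loss of the tert-butyl or ethyl group. Also open, on these data alone, is how a link carrying a 4-tert-butylcyclohexyl ring, a saturated 2-cyclohexylethyl chain or an amine on the ring would compare.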